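The source may hold more compounds than are shown below. What is called first, only, known or untested is meant among the compounds shown, and "the series" means these compounds.

Among the compounds with values here, in an ADME assay on HUVEC cells (Homo sapiens) for antiproliferative activity, read by resazurin assay, with a stated time of 72 h (on this read-out lower numbers stand for stronger inhibition of growth and higher numbers for weaker inhibition of growth), compound 3 (`CN(C)C1=NN(c2ccc(Cl)cc2)CN(c2ccccc2Cl)C1=O`) gives 16.1 ug/mL, the lowest of the numbers measured so far. Compound 2 (`O=C1C(N2CCCC2)=NN(c2ccccc2)CN1c1ccccc1Cl`) gives 40.9 ug/mL, a higher number and beyond the scatter. Compound 1 (`O=C1C(N2CCCCC2)=NN(c2ccc(Cl)cc2)CN1c1ccccc1Cl`) gives > 50 ug/mL, which is a limit of the assay and not a number.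

The next compound, compound 4 (`O=C1C(N2CCCC2)=NN(c2ccc(Cl)cc2)CN1c1ccccc1Cl`), differs from compound 3 in one place: it has pyrrolidin-1-yl in place of dimethylamino on a carbon with a double bond to nitrogen. Within the data shown here, the one measured step at this place is an at least 3.1-fold lower number from compound 1 to compound 3 (0.49 log units; beyond the scatter), with dimethylamino replacing piperidin-1-yl. That step starts from a limit, so its true size is not known. It suggests that leaving dimethylamino for a ring may raise the number in this assay. Compound 2, which also carries pyrrolidin-1-yl, gives 40.9 ug/mL, and this points the same way. A small upward move is therefore expected, and the expected step is a 2.2-fold higher number from compound 3 to compound 4 (0.34 log units; beyond the scatter). Compound 4 is estimated at 35 ug/mL, with an expected range of 18 ug/mL to 65 ug/mL.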

Compound 4, concentration for 50% growth inhibition in the HUVEC assay: 18.9 ug/mL
Compound 4: the middle estimate sits 1.9-fold (0.27 log units) above what was measured; the measured number falls inside the stated range.
By their numbers in the HUVEC assay, from the lowest: compounds 3 and 4 (each within the scatter of the next); then compound 2. At a limit, above all of these: compound 1.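

In the HUVEC assay, pyrrolidin-1-yl in place of dimethylamino gives a 1.2-fold higher number from compound 3 to compound 4 (0.07 log units; within the scatter), so the ring does not separate the two compounds on this read-out, although the same change does separate them in a physicochemical assay for lipophilicity, read by HPLC, measured as octanol-water partition; on this read-out lower numbers stand for lower lipophilicity and higher numbers for higher lipophilicity: the measured partition coefficient of compound 3, 4.2, and of compound 4, 4.6, a number 0.40 log units higher (beyond the scatter) In the physicochemical assay compound 3 gives 4.2 and compound 4 gives 4.6. In the HUVEC assay compound 1 stands at a limit of the assay, so an at least 2.6-fold lower number from compound 1 to compound 4 (0.42 log units; beyond the scatter), with pyrrolidin-1-yl in place of piperidin-1-yl, has no known true size. In the HUVEC assay, chloro in place of hydrogen on an aromatic carbon gives a 2.2-fold lower number from compound 2 to compound 4 (0.34 log units; beyond the scatter), so pyrrolidin-1-yl alone does not set the number of compound 2.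

The compounds shown leave open whether morpholin-4-yl, a ring with a further hetero atom, or diethylamino, an open chain longer than dimethylamino, would fit at this place. They also leave open how far these numbers would hold on a core without the 4-chlorophenyl group.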